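Enone amide series: chain unsaturation at the carbonyl

The source may hold more compounds than are shown below. What is called first, only, known or untested is meant among the compounds shown, and "the series" means these compounds.

Measured so far in a functional assay on HCT-116 cells (Homo sapiens) for inhibition, read by MTT assay, with a stated time of 48 h; on this read-out higher numbers stand for weaker inhibition and lower numbers for stronger inhibition:
compound 1 `CCC/C=C/C(=O)N(Cc1ccc(OC)c(O)c1)c1cc(OC)c(OC)c(OC)c1` — 95 nM
compound 2 `COc1ccc(CN(C(=O)CCl)c2cc(OC)c(OC)c(OC)c2)cc1O` — 250 nM
compound 3 `C/C=C/C(=O)N(Cc1cc(OC)c(OC)c(OC)c1)c1ccc(OC)c(O)c1` — 8450 nM

Compound 1 stands lowest of the three numbers on this assay. Its nearest neighbour is compound 2, reached by a 2.6-fold higher number from compound 1 to compound 2 (0.42 log units; beyond the scatter), a change of the group on the carbonyl carbon. Going by the values given here, compound 3 carries the same side groups but with the two aryl parts exchanged, and the values of compound 1 and compound 3 lie far apart on this assay; no single-point step links them.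

Compound 4 `C/C=C/C=C/C(=O)N(Cc1ccc(OC)c(O)c1)c1cc(OC)c(OC)c(OC)c1` is the next candidate. It differs from compound 1 as follows: prop-1-en-1-yl in place of propyl on a double-bonded chain carbon bound to a double-bonded chain carbon. Among the compounds with values here, the one measured step that touches the carbonyl substituent, from compound 1 to compound 2, replaced the whole pent-1-en-1-yl chain with chloromethyl and was modest; here only the outer propyl part becomes prop-1-en-1-yl while the chain length and the double-bonded chain carbon bound to the carbonyl stay. Within the data shown here, no measured pair shows this particular change, so the expected step from compound 1 to compound 4 on this assay is small, likely within the scatter, with no direction favoured: a 1.3-fold higher number from compound 1 to compound 4 (0.10 log units; within the scatter). Compound 4 is therefore estimated at 120 nM, between 40 nM and 360 nM.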

Compound 4, half-maximal inhibitory concentration: 180 nM
Estimate against measurement, compound 4: 1.5-fold (0.18 log units) below, within the range that was stated.
By their numbers in this assay, from the lowest: compounds 1, 4 and 2 (each within the scatter of the next, the first and the last beyond it); then compound 3.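

In this assay, prop-1-en-1-yl in place of propyl on the double-bonded chain carbon gives a 1.9-fold higher number from compound 1 to compound 4 (0.28 log units; within the scatter) and so the second chain double bond, which turns pent-1-en-1-yl into penta-1,3-dien-1-yl, leaves this pair inside the scatter. On the carbonyl carbon, penta-1,3-dien-1-yl in place of chloromethyl likewise stays inside the scatter, with a 1.4-fold lower number from compound 2 to compound 4 (0.14 log units; within the scatter) while pent-1-en-1-yl and chloromethyl on that same carbon remain separated by a 2.6-fold higher number from compound 1 to compound 2 (0.42 log units; beyond the scatter) and compound 4 therefore lies within the scatter of both of two compounds that are themselves apart. No supporting measurement on hand speaks to the reason for these numbers.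

Still open, as far as these compounds go, is how this carbonyl substituent would read with a fully saturated pentyl chain, a longer conjugated chain such as hepta-1,3,5-trien-1-yl, or an amine such as dimethylaminomethyl in place of chloromethyl. The compounds shown also offer no single-place route to compound 3, so which part of its exchanged arrangement carries its number remains unresolved.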